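This account rests on a few compounds, and the source may have more. Where it says the series, first, only, none or still open, it means among the compounds named here.

Series at a glance:
compound 1 `O=C(CN(c1nc(Cl)nc2[nH]cnc12)C1CC1)N[C@@H](CO)C(=O)OCc1ccccc1`: 34.5%
compound 2 `O=C(OCc1ccccc1)[C@@H]1CCCN1C(=O)CN(c1nc(Cl)nc2[nH]cnc12)C1CC1`: 43.3%
compound 3 `O=C(CN(c1nc(Cl)nc2[nH]cnc12)C1CC1)N[C@@H](CO)C(=O)O`: 43.9%

All three were read in a functional assay on the whole organism (Tail, strain ICR) with Mus musculus as the target, in the tail flick test, with a stated time of 90 min, at a dose of 25 umol/kg by the oral route; on this read-out lower numbers stand for a weaker effect and higher numbers for a stronger effect at the one dose given. Compound 1 sits at the lower end of the three numbers, but its gaps to compound 2 and to compound 3 are both within the scatter, so the three compounds cannot be told apart on this read-out. Within the data shown here, the one single-point step measured so far, a number 9.4 percentage points higher from compound 1 to compound 3 (within the scatter), touches only the ester end of the side chain and changes nothing beyond the scatter; compound 2 carries no step of its own to compound 1 and its value simply lies within scatter of that of compound 1.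

Compound 4 `NC(=O)CC[C@H](NC(=O)CN(c1nc(Cl)nc2[nH]cnc12)C1CC1)C(=O)OCc1ccccc1` is not yet measured. It differs from compound 1 by carbamoylmethyl in place of hydroxy on a saturated chain carbon, two bonds along the chain from an amide-type nitrogen and a carbonyl carbon. Among the measured compounds shown here, no measured step touches that chain carbon, so the only guide is the general flatness of this assay across the ester change. The step of a number 1.5 percentage points higher from compound 1 to compound 4 (within the scatter) is therefore expected to stay within the scatter. Compound 4 is estimated at 36%, with a range from 22% to 50%.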

Compound 4, a percentage reported as activity, at one dose (the size of the read-out at that dose, not a potency): 42.8%
The estimate for compound 4 lay 6.8 percentage points below the measured number; measured number inside the range.
By their numbers in this assay, from the lowest: compounds 1, 4, 2 and 3 (each within the scatter of the next).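

In this assay, among these compounds, the step of a number 8.3 percentage points higher from compound 1 to compound 4 (within the scatter) is the first measured change at this saturated chain carbon, and it stays within the scatter. Read one bond further out, hydroxymethyl to 2-carbamoylethyl, this exchange brings in a group of 4 heavy atoms for one of 1 heavy atom, with the same hydrogen-bond donor and acceptor counts, and the read-out does not separate the pair. Nothing available explains why this change leaves the read-out within the scatter.

Still open, as far as these compounds go, is whether an amine, a carboxylic acid or a longer alkyl chain at this carbon would give a step beyond the scatter. Also open, from the compounds shown here alone, is whether a free carboxylic acid in place of the benzyl ester of compound 4 would stay as flat as the same change does on compound 1.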